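Side-chain swaps on a shared core: compound 3 to compound 4

The source may report more compounds than this note shows. Statements on the series, on what has been measured and on what is new or still open speak of the compounds shown alone.

Measured, with values in a functional assay on MCF7 cells (Homo sapiens) for antiproliferative activity, read by MTT assay, with a stated time of 72 h; a lower number here means a stronger inhibitor, a higher number a weaker inhibitor:
Compound 1, `CCCCc1cn(C[C@H](O)[C@H]2OC(=O)C(OCc3ccccc3)=C2OCc2ccccc2)nn1`: 7910 nM
Compound 2, `O=C1O[C@H]([C@@H](O)Cn2cc(CNS(=O)(=O)c3ccc(F)cc3)nn2)C(OCc2ccccc2)=C1OCc1ccccc1`: 26800 nM
Compound 3, `O=C1O[C@H]([C@@H](O)Cn2cc(CCO)nn2)C(OCc2ccccc2)=C1OCc1ccccc1`: 63400 nM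

Compound 3 gives the highest number of the three. Its nearest neighbour is compound 2, separated by a 2.4-fold higher number from compound 2 to compound 3 (0.37 log units; beyond the scatter); the furthest is compound 1, separated by an 8.0-fold higher number from compound 1 to compound 3 (0.90 log units; beyond the scatter). Between the other two stands a 3.4-fold higher number from compound 1 to compound 2 (0.53 log units; beyond the scatter).

Compound 4 is `O=C1O[C@H]([C@@H](O)Cn2cc(CNS(=O)(=O)c3ccc(Cl)cc3F)nn2)C(OCc2ccccc2)=C1OCc1ccccc1`. Against compound 3 the change is ((4-chloro-2-fluorophenyl)sulfonyl)amino in place of hydroxymethyl on a saturated chain carbon bound to an aromatic carbon. The measured step that bears on it is a 2.4-fold higher number from compound 2 to compound 3 (0.37 log units; beyond the scatter), read backwards: compound 2 carries a sulfonylamino group of the same kind in the same place, and going from hydroxymethyl to that group lowered the number by a modest amount. For the measured compounds named here, the ring of compound 4 carries a chlorine and a fluorine rather than a fluorine alone, and no measured pair shows what such a ring change does, so it adds uncertainty rather than direction. The expectation for compound 4 in this assay is thus a modest drop, roughly the size of the step from compound 2 to compound 3 undone, with room on either side; the estimated step is a 3.2-fold lower number from compound 3 to compound 4 (0.50 log units; beyond the scatter). Compound 4 is expected near 20000 nM, within 8000 nM to 50000 nM.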

Compound 4, half-maximal inhibitory concentration: 3390 nM
Estimate against measurement, compound 4: 5.9-fold (0.77 log units) above; the whole stated range lies above it.
By their numbers in this assay, from the lowest: compound 4; then compound 1; then compound 2; then compound 3.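

In this assay, the sulfonylamino side chain does not fix the number on its own: with only 4-chloro-2-fluorophenyl in place of 4-fluorophenyl on the sulfonyl sulfur, the reading improves (a 7.9-fold lower number from compound 2 to compound 4 (0.90 log units; beyond the scatter)), so the ring on the sulfur counts for a substantial share of the result at this position. For the compounds shown here, replacing hydroxymethyl with ((4-chloro-2-fluorophenyl)sulfonyl)amino gives the only large step in the set (a 19-fold lower number from compound 3 to compound 4 (1.27 log units; beyond the scatter)), well beyond what the sulfonylamino group of compound 2 achieved against the same hydroxymethyl (a 2.4-fold higher number from compound 2 to compound 3 (0.37 log units; beyond the scatter)). The order against the propyl-bearing end of the chain also reverses: compound 2 lay on the weaker side of compound 1 (a 3.4-fold higher number from compound 1 to compound 2 (0.53 log units; beyond the scatter)), whereas the new ring puts the sulfonylamino series on the stronger side (a 2.3-fold lower number from compound 1 to compound 4 (0.37 log units; beyond the scatter)).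

Open, on these data alone, is whether the chlorine or the added fluorine carries the gain, and how an amine or a carboxylic acid on the same saturated chain carbon would read in this assay. No measurement at hand gives a reason for the size of the ring effect.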